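The compounds below may be only part of what the source reports. "The series", "measured", "known", "first", "only" and "open" are said of these compounds alone.

Measured compounds:
compound 1 `COc1ccc(Cl)cc1S(=O)(=O)NC(=O)NC/C=C1\CCCc2cnn(Cc3ccc(Cl)cc3Cl)c21` – 8 nM
compound 2 `Cc1nc(C)c(S(=O)(=O)NC(=O)NC/C=C2\CCCc3cnn(Cc4ccc(Cl)cc4Cl)c32)s1` – 4 nM
compound 3 `O=C(NC/C=C1\CCCc2cnn(C3CCN(c4ccc(F)cc4)CC3)c21)NS(=O)(=O)c1cc(Cl)c(Cl)s1` – 6 nM

The three compounds share a core and differ in the group on the sulfonyl sulfur. In a functional assay on CHO-K1 cells for antagonist activity at prostaglandin E2 receptor EP3 subtype (Homo sapiens), read by TR-FRET and cAMP accumulation, with a stated time of 30 min (a lower number here means a stronger inhibitor, a higher number a weaker inhibitor), compound 1 gives 8 nM, the highest of the three numbers, though all three lie within the scatter of one another: compound 3 sits closest, compound 2 furthest, and no order can be read from them.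

Compound 4 `Cn1cc(S(=O)(=O)NC(=O)NC/C=C2\CCCc3cnn(Cc4ccc(Cl)cc4Cl)c32)cn1` has not been measured. It differs from compound 1 in one place: 1-methyl-1H-pyrazol-4-yl in place of 5-chloro-2-methoxyphenyl on a sulfonyl sulfur. Going by the values given here, the one measured step that bears on it is a 2.0-fold lower number from compound 1 to compound 2 (0.30 log units; within the scatter), an exchange of the same phenyl group for a five-membered heteroaryl on the same sulfur, which left the number within the scatter. Because of a 2.0-fold lower number from compound 1 to compound 2 (0.30 log units; within the scatter), a heteroaryl group on the sulfonyl sulfur is expected to be tolerated, and no step beyond the scatter is expected in this assay for compound 4 in either direction. Compound 4 is therefore estimated at 10 nM, within 3 nM to 35 nM, an expected step of a 1.3-fold higher number from compound 1 to compound 4 (0.10 log units; within the scatter).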

Compound 4, half-maximal inhibitory concentration: 8 nM
Beside the measured number, compound 4's estimate is 1.3-fold (0.10 log units) above it; measured number inside the range.
By their numbers in this assay, from the lowest: compounds 2, 3, 1 and 4 (each within the scatter of the next).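

In this assay, replacing the group on the sulfonyl sulfur gives no change at the digits printed from compound 1 to compound 4 (within the scatter), and a 2.0-fold higher number from compound 2 to compound 4 (0.30 log units; within the scatter), so neither exchange moves the number beyond the scatter. Compound 4 thus extends what compound 2 first suggested: a second five-membered aromatic ring, here with 2 hetero atoms, can stand on this sulfur, and the position also accepts a group of 6 heavy atoms in place of one of 9, without the chlorine or oxygen of the 5-chloro-2-methoxyphenyl group. Nothing shown explains why the number stays so flat across these groups.

The compounds shown leave open whether this sulfur also accepts a group with no aromatic ring, such as a plain methyl or cyclopropyl, or a ring carrying an amine or a carboxylic acid. Also open, on these data alone, is whether 1-methyl-1H-pyrazol-4-yl behaves the same way on the core of compound 3.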